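This account rests on a few compounds, and the source may have more. Where it says the series, first, only, none or still open, it means among the compounds named here.

Compound 1 `O=C(Nc1cc(C(F)(F)F)ccc1N1CCCC1)c1cccnc1Cl`, "not active" (no number reported); compound 2 `O=C(Nc1cc(C(F)(F)F)ccc1N1CCCCC1)c1cccnc1Cl`, "not active" (no number reported); compound 3 `O=C(Nc1cc(C(F)(F)F)ccc1Nc1ccc(Br)cc1)c1ccccc1`, 6000 nM.

In a functional assay on NALM-6 cells (Homo sapiens) for cytotoxicity, read by MTT assay, with a stated time of 48 h (on this read-out lower numbers stand for stronger inhibition and higher numbers for weaker inhibition), compound 1 gives "not active" (no number reported), so no number stands behind it and it cannot be placed on a scale against the others. In this assay compound 2 gives "not active" (no number reported) as well, again without a number. Within the data shown here, only compound 3 carries a figure, giving 6000 nM in this assay, and even that lies in the weak range; compound 3 shares with compound 1 the trifluoromethyl-bearing core but differs in several places, so it offers no step to compare.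

Compound 4 `O=C(Nc1cc(C(F)(F)F)ccc1N1CCCC1)c1cccnc1` differs from compound 1 by hydrogen in place of chloro on an aromatic carbon. Among the measured compounds shown here, no pair of measured compounds shows what this change does in this assay, so its size and direction are open; with compound 1 reported without a number, the change is expected to leave compound 4 in the same weak region rather than move it beyond the scatter. Compound 4 is therefore expected to give about 20000 nM in this assay, estimated between 5000 nM and 80000 nM, with a real chance that only a limit is reported.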

Compound 4, half-maximal inhibitory concentration: "not active" (no number reported)
No number was reported for compound 4; no gap can be computed for the estimate.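

In this assay compound 1 and compound 4 both come without a number, so no step can be read between them. Whether the change from 2-chloropyridin-3-yl to pyridin-3-yl shifts the response at all stays open, and no evidence shown bears on this result.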